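Benzofuran carboxamide acids: cyclopropyl acid estimate

A few compounds are considered here, and "the series" means these few. Any claim that something is new, unique, unknown or untested is made for them only; others in the source may bear on it.

Measured compounds:
compound 1 `O=C(NC1(C(=O)O)CCCCC1)c1cccc2c(Br)c(-c3ccc(Cl)cc3)oc12`, > 30000 nM
compound 2 `CC(C)(NC(=O)c1cc(F)cc2cc(-c3ccc(Cl)cc3)oc12)c1nnn[nH]1`, "not determined" (no result reported)
compound 3 `C[C@H](NC(=O)c1cc(F)cc2cc(-c3ccc(Cl)cc3)oc12)C(=O)O`, "not determined" (no result reported)

In an assay on isolated protein for inhibition of endoplasmic reticulum aminopeptidase 2 (Homo sapiens) (on this read-out lower numbers stand for stronger inhibition and higher numbers for weaker inhibition), compound 1 gives only a limit, > 30000 nM, which is the assay limit of > 30000 nM in this assay, at which 1 of the 3 values shown sits, and not a number. For compound 2 this assay returns "not determined" (no result reported). For compound 3 this assay likewise returns "not determined" (no result reported). Within the data shown here, compound 3 therefore stands nowhere on a numerical scale: of the three values shown, one is a limit and two carry no result, so no measured step can be sized or given a direction.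

Compound 4 `O=C(NC1(C(=O)O)CC1)c1cc(F)cc2cc(-c3ccc(Cl)cc3)oc12` is the next member. It differs from compound 3 in one place: 1-carboxycyclopropyl in place of 1-carboxyethyl on an amide-type nitrogen. Among the measured compounds shown here, no measured step runs from compound 3 to compound 4, and none between any other pair, so the size and direction of the change in this assay cannot be read from the series; the expectation below rests on the structural change alone and on the fact that the one recorded value, for compound 1, is a limit.

For compound 4 the expected value in this assay is 5000 nM, with a range from 500 nM to 30000 nM, and a real chance that only a limit is returned.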

Compound 4, half-maximal inhibitory concentration: > 30000 nM
Compound 4 was reported as a limit; the forecaster's own chance of this, stated with the estimate: 40%; at least 6.0-fold (0.77 log units) between middle value and limit.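

In this assay compound 4 gives > 30000 nM, which is a limit and not a number. Among these compounds, compound 3 has no single number there, so no step to compound 4 can be read. The compounds shown leave open how 1-carboxyethyl and 1-carboxycyclopropyl on the amide-type nitrogen compare, since the recorded values stop at one limit: the limit of > 30000 nM in this assay, at which 2 of the 4 values shown sit.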